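A few compounds are considered here, and "the series" means these few. Any claim that something is new, unique, unknown or untested is made for them only; others in the source may bear on it.

Measured in a functional assay on LN-229 cells (Homo sapiens) for antiproliferative activity, with a stated time of 72 h; on this read-out lower numbers stand for stronger inhibition and higher numbers for weaker inhibition:
Compound 1 `CCCC#Cc1cc([C@@H]2O[C@H](CO)[C@@H](O)[C@H]2O)n2ncnc(N)c12`: 40 nM
Compound 2 `CCCCC#Cc1cc([C@@H]2O[C@H](CO)[C@@H](O)[C@H]2O)n2ncnc(N)c12`: 1000 nM

Of these two, compound 2 has the higher number, at 1000 nM, which makes it the weaker inhibitor of the pair. The next compound to consider is compound 3 `Nc1ncnn2c([C@@H]3O[C@H](CO)[C@@H](O)[C@H]3O)cc(C#CC3CC3)c12`. It keeps the shared core but swaps one group: cyclopropyl in place of butyl on a triple-bonded carbon. Put simply, it has cyclopropyl in place of butyl on a triple-bonded carbon.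

Among the compounds with values here, only one measured step bears on this change: a 25-fold higher number from compound 1 to compound 2 (1.40 log units; beyond the scatter). That step came from a methyl in place of hydrogen on a saturated chain carbon, three bonds along the chain from a triple-bonded carbon. It shows that a small edit to this chain can shift the number a long way. Compound 3 gives up the butyl group, so a move back towards compound 1 seems likely. Within the data shown here, still, no measured compound carries a ring here, and a single step is thin evidence. The expected change is a 17-fold lower number from compound 2 to compound 3 (1.22 log units; beyond the scatter), a large drop in the number. For compound 3 the estimated value is 60 nM, with an expected range of 10 nM to 400 nM.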

Compound 3, half-maximal inhibitory concentration: 30 nM
Beside the measured number, compound 3's estimate is 2.0-fold (0.30 log units) above it; low and high end bracket the measured number.
By their numbers in this assay, from the lowest: compounds 3 and 1 (each within the scatter of the next); then compound 2.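

Replacing butyl with cyclopropyl on a triple-bonded carbon in this assay gives a 33-fold lower number from compound 2 to compound 3 (1.52 log units; beyond the scatter), so the earlier penalty seen with butyl does not extend to every group at this position, and a ring can stand there in place of an open chain. Cyclopropyl in place of propyl gives a 1.3-fold lower number from compound 1 to compound 3 (0.12 log units; within the scatter), which puts the ring and the shorter chain on level terms and leaves butyl as the only one of the three groups with a clearly different number. The data offer no independent measurement that explains why butyl stands apart from propyl and cyclopropyl.

As far as these compounds go, with only these three groups to compare, it remains open whether the number stays low for larger rings such as cyclobutyl or cyclopentyl, or climbs towards that of compound 2 as the ring grows. From the compounds shown here alone, it is also open how a branched chain such as isopropyl, or a chain ending in a hydroxyl or an amine, would behave on this same triple-bonded carbon.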